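Chromone ethers: replacing pyridinyl with methoxyphenyl

The source may report more compounds than this note shows. Statements on the series, on what has been measured and on what is new or still open speak of the compounds shown alone.

Measured in an assay on isolated protein (Cavia porcellus) with Sigma non-opioid intracellular receptor 1 (Homo sapiens) as the target, read by radioligand binding; a lower number here means a stronger inhibitor, a higher number a weaker inhibitor:
compound 1 `CN(C)CCCCOc1ccc2oc(-c3ccccc3)cc(=O)c2c1`: 400 nM
compound 2 `O=c1cc(-c2ccccc2Cl)oc2ccc(OCCCCCCN3CCC(O)CC3)cc12`: 29 nM
compound 3 `O=c1cc(-c2cccnc2)oc2ccc(OCCCCCCN3CCC(O)CC3)cc12`: 210 nM

Compound 3 stands second highest of the three numbers; compound 1 lies within the scatter of it, while compound 2 sits well below. The step to compound 4 `COc1ccc(-c2cc(=O)c3cc(OCCCCCCN4CCC(O)CC4)ccc3o2)cc1` is 4-methoxyphenyl in place of pyridin-3-yl on an aromatic carbon. Going by the values given here, the one step that bears on it is a 7.2-fold higher number from compound 2 to compound 3 (0.86 log units; beyond the scatter), where a carbocyclic aryl group in place of the pyridinyl lowered the number beyond the scatter. A similar direction is expected here, though a smaller size, since no chloro-bearing ring enters. For compound 4 an estimate of 70 nM is given, within 25 nM to 200 nM, which means an expected step of a 3.0-fold lower number from compound 3 to compound 4 (0.48 log units; beyond the scatter) in this assay.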

Compound 4, half-maximal inhibitory concentration: 332 nM
Beside the measured number, compound 4's estimate is 4.7-fold (0.68 log units) below it; measured number outside the range, above it.
By their numbers in this assay, from the lowest: compound 2; then compounds 3, 4 and 1 (each within the scatter of the next).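

In this assay, a 1.6-fold higher number from compound 3 to compound 4 (0.20 log units; within the scatter) shows that 4-methoxyphenyl and pyridin-3-yl cannot be told apart at this position next to the ring oxygen. Against the 2-chlorophenyl group, an 11-fold higher number from compound 2 to compound 4 (1.06 log units; beyond the scatter), so a ring of carbon only does not by itself go with the lower number; of these three groups, 2-chlorophenyl alone stands apart. No evidence bearing on this result is available. On these data alone, what remains open is whether the chlorine or its place on the ring goes with that lower number, and what 4-chlorophenyl or 2-methoxyphenyl would give at this carbon.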